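Swapping the Naphthalene Arm for a Methylfuran Ring

This account rests on a few compounds, and the source may have more. Where it says the series, first, only, none or still open, it means among the compounds named here.

Compound 1 `COc1cc(N2C(N)=C(C#N)C(c3ccc(OC)c4ccccc34)C3=C2CC(C)(C)CC3=O)cc(OC)c1OC` gives 10% in a functional assay on Ehrlich cells (Mus musculus) for cytotoxicity, tested at 10 ug/mL (a lower number here means a weaker effect, a higher number a stronger effect of the compound at the concentration tested), where it stands second highest of the three numbers measured. Compound 2 `COc1cc(N2C(N)=C(C#N)C(c3c(O)ccc4ccccc34)C3=C2CC(C)(C)CC3=O)cc(OC)c1OC` gives 2%, and the step of a number 8 percentage points lower from compound 1 to compound 2 (within the scatter) lies within the scatter. Compound 3 `COc1cc(N2C(N)=C(C#N)C(c3ccc(Cl)cc3Cl)C3=C2CC(C)(C)CC3=O)cc(OC)c1OC` gives 20% in this assay, and the step of a number 10 percentage points higher from compound 1 to compound 3 (within the scatter) also lies within the scatter. Among the compounds with values here, only the step of a number 18 percentage points higher from compound 2 to compound 3 (beyond the scatter) reaches beyond it, and even that step is modest.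

Compound 4 `COc1cc(N2C(N)=C(C#N)C(c3ccc(C)o3)C3=C2CC(C)(C)CC3=O)cc(OC)c1OC` has not yet been measured. It differs from compound 1 in one place: 5-methylfuran-2-yl in place of 4-methoxynaphthalen-1-yl on a saturated ring carbon. Both measured steps away from compound 1 exchange the same 4-methoxynaphthalen-1-yl group at the same saturated ring carbon for another aromatic group, and neither moves the read-out beyond the scatter. A third exchange at this place is therefore expected to behave alike, so the expected step of a number 2 percentage points higher from compound 1 to compound 4 (within the scatter) is small, not clearly beyond the scatter in either direction. Compound 4 is accordingly estimated at 12%, with a range from 2% to 25%.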

Compound 4, a percentage reported as activity, at one concentration (the size of the read-out at that concentration, not a potency): 21%
Estimate against measurement, compound 4: 9 percentage points below; low and high end bracket the measured number.
By their numbers in this assay, from the lowest: compounds 2, 1, 3 and 4 (each within the scatter of the next, the first and the last beyond it).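

In this assay the step of a number 11 percentage points higher from compound 1 to compound 4 (beyond the scatter) shows that an exchange at this saturated ring carbon can move the read-out beyond the scatter, which neither earlier exchange from compound 1 did, and here one five-membered aromatic ring enters where two six-membered aromatic rings leave. The 5-methylfuran-2-yl group also stands clear of the 2-hydroxynaphthalen-1-yl group in the step of a number 19 percentage points higher from compound 2 to compound 4 (beyond the scatter) but not of the 2,4-dichlorophenyl group in the step of a number 1 percentage points higher from compound 3 to compound 4 (within the scatter) and so these last two groups cannot be told apart in this assay. No measurement at hand explains these differences.

On these data alone, all four groups are aromatic, so it remains open how a cyclohexyl ring, a longer alkyl chain or a group carrying an amine or a carboxylic acid would read at this carbon. As far as these compounds go, it is also open whether the methyl on the furan matters, since no furan without it appears here.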